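Swapping Chloro for Amino on a Shared Core

This account rests on a few compounds, and the source may have more. Where it says the series, first, only, none or still open, it means among the compounds named here.

Compound 2 `Nc1nn(C(=O)Nc2ccc(Cc3ccccc3)cc2)c2ccc(Cl)cc12` carries a chloro group on its core; in a functional assay on NCI-H226 cells (Homo sapiens) for antiproliferative activity, read by sulforhodamine B assay, with a stated time of 48 h (on this read-out lower numbers stand for stronger inhibition of growth and higher numbers for weaker inhibition of growth), compound 2 gives 15400 nM, the highest of the two numbers shown. Within the data shown here, its only measured neighbour, compound 1 `Nc1nn(C(=O)Nc2ccc(Cc3ccccc3)cc2)c2ccccc12`, bears hydrogen in that place and gives 13500 nM, a step of a 1.1-fold higher number from compound 1 to compound 2 (0.06 log units; within the scatter). Compound 3 `Nc1ccc2c(c1)c(N)nn2C(=O)Nc1ccc(Cc2ccccc2)cc1` arises by amino in place of chloro on an aromatic carbon. Among the measured compounds shown here, because the one change measured at that place, a 1.1-fold higher number from compound 1 to compound 2 (0.06 log units; within the scatter), stayed within the scatter, compound 3 is estimated at 14000 nM, between 5000 nM and 40000 nM, an expected step of a 1.1-fold lower number from compound 2 to compound 3 (0.04 log units; within the scatter) that lies within the scatter.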

Compound 3, concentration for 50% growth inhibition: 16100 nM
Compound 3: middle estimate off by 1.2-fold (0.06 log units), on the low side; the measured number falls inside the stated range.
By their numbers in this assay, from the lowest: compounds 1, 2 and 3 (each within the scatter of the next).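

Amino in place of chloro gives a 1.0-fold higher number from compound 2 to compound 3 (0.02 log units; within the scatter) in this assay and amino in place of hydrogen gives a 1.2-fold higher number from compound 1 to compound 3 (0.08 log units; within the scatter) and so hydrogen, chloro and amino all read alike at this place on the shared core. Amino brings a hydrogen-bond donor and acceptor that chloro lacks, yet the number stays within the scatter. No measured evidence bears on why this is so. From the compounds shown here alone, whether a carboxylic acid or a longer chain at this place would move the number beyond the scatter stays open.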